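A few compounds are considered here, and "the series" means these few. Any claim that something is new, unique, unknown or untested is made for them only; others in the source may bear on it.

Three compounds built on one shared core have been examined in an ADME assay on Vero cells (Chlorocebus sabaeus) for cytotoxicity, read by XTT assay, with a stated time of 72 h; a higher number here means that more compound is tolerated, a lower number that less compound is tolerated. Compound 1 `CC1=C(C(=O)NC2CCCCC2)C(c2ccccc2)NC(=O)N1` gives > 100000 nM in this assay, which is a limit of the assay rather than a number. Compound 2 `CC1=C(C(=O)Nc2ccccc2Cl)C(c2ccccc2Cl)NC(=O)N1` is reported in this assay as "non-toxic" (no number reported), with no number given. Compound 3 `CC1=C(C(=O)Nc2ccccc2Cl)C(c2ccc(C)cc2)NC(=O)N1` gives > 100000 nM in this assay, again a limit and not a number. Compound 3 therefore stands at the top of what has been seen here, alongside compound 1, and the entry without a number for compound 2 points the same way; two of the three values sit at the limit (the limit of > 100000 nM in this assay, at which 2 of the 3 values shown sit). Going by the values given here, no step between measured compounds can be computed from these data. Compound 4 `COc1ccc(C2NC(=O)NC(C)=C2C(=O)Nc2ccccc2Cl)cc1` differs from compound 3 by methoxy in place of methyl on an aromatic carbon. Because the values sit at the limit (the limit of > 100000 nM in this assay, at which 2 of the 3 values shown sit), the step expected in this assay is a number no higher from compound 3 to compound 4 (the limit leaves the size open). Compound 4 is expected to give 100000 nM, between 50000 nM and 200000 nM, and most likely again only as a limit.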

Compound 4, half-maximal cytotoxic concentration: > 100000 nM
Compound 4 was reported as a limit; the forecaster's own chance of this, stated with the estimate: 85%; the middle value sits exactly at the limit.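

Compound 3 and compound 4 both stand only as limits in this assay, so no step between them can be read: the limit of > 100000 nM in this assay, at which 3 of the 4 values shown sit.

The compounds shown leave open whether 4-methylphenyl and 4-methoxyphenyl differ at all here, and how much compound is actually tolerated past that limit.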